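The compounds below may be only part of what the source reports. "The series", "measured", "known", "first", "only" and "open" are said of these compounds alone.

Working notes on the series in a functional assay on HepG2 cells (Homo sapiens) for cytotoxicity, read by MTT assay, with a stated time of 48 h; a lower number here means a stronger inhibitor, a higher number a weaker inhibitor. Of the compounds shown here, two have been measured. Compound 1 `CC1=NN(S(=O)(=O)c2ccc([N+](=O)[O-])cc2)C(c2cc(Cl)ccc2O)C1` is recorded in this assay as "not active" (no number reported), with no number reported, so it gives no point of comparison. Within the data shown here, compound 2 `CCC(=O)N1N=C(c2cc3ccccc3oc2=O)CC1c1ccccc1` is therefore the only compound with a number: in this assay compound 2 gives 9610 nM, and it stands alone on that scale, neither strong nor weak relative to anything else measured here.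

The next compound, compound 3 `O=C(CN1CCC(O)CC1)N1N=C(c2cc3ccccc3oc2=O)CC1c1ccccc1`, keeps the whole of compound 2 apart from one change: 4-hydroxypiperidin-1-yl in place of methyl on a saturated chain carbon bound to a carbonyl carbon. The propanoyl of compound 2 becomes a ((4-hydroxypiperidin-1-yl)methyl)carbonyl in compound 3.

Among the measured compounds shown here, no measured pair in this set shares such a change, so there is nothing to calibrate the step against. A modest step is expected from compound 2 to compound 3, most likely toward a weaker inhibitor but possibly none beyond the scatter, as a 1.5-fold higher number from compound 2 to compound 3 (0.16 log units; within the scatter). Compound 3 is accordingly estimated at 14000 nM in this assay, within a range from 4500 nM to 45000 nM, with a real chance that only an inactive call is returned.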

Compound 3, half-maximal inhibitory concentration: "not active" (no number reported)
The entry for compound 3 holds no number; the estimate stays without a comparison.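

In this assay, among these compounds, compound 3 gives "not active" (no number reported), so no step from compound 2 to compound 3 can be read. The compounds shown leave open how far the propanoyl of compound 2 can be changed at the saturated chain carbon while a number is still returned. Nothing available here bears on this result.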